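Methyl on the five-membered ring in two cores

The compounds below may be only part of what the source reports. "The series", "measured", "known", "first", "only" and "open" are said of these compounds alone.

Compound 1 `CC(=O)N(C)C(C)C#CCn1ccnc1` and compound 2 `CC(=O)N(C)C(C)C#CCn1ccnc1C` are built on one core; compound 3 `CN1CCN(CC#CCn2ccnc2)C1=O` and compound 4 `Cc1cncn1CC#CCN1CCN(C)C1=O` on another, and the difference between the two cores is not broken down here. In a functional assay on the whole organism for antagonist activity, with Mus musculus as the target (a lower number here means that less compound is needed, a higher number that more compound is needed for the effect), compound 1 reaches only a limit of the assay, > 100 mg/kg. Compound 2 gives 0.2 mg/kg in this assay. The change between them, (methyl in place of hydrogen on an aromatic carbon), brings an at least 500-fold lower number from compound 1 to compound 2 (2.69 log units; beyond the scatter). Compound 3 also reaches only a limit of the assay, > 100 mg/kg. Two of the three values seen so far sit at this limit (the limit of > 100 mg/kg in this assay, at which 2 of the 3 values shown sit).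

Compound 4 carries the same kind of change on its core, (methyl in place of hydrogen on an aromatic carbon), but not the same change: in compound 2 the methyl sits between two ring nitrogen atoms, whereas in compound 4 it sits next to the ring nitrogen, two ring bonds from the ring nitrogen. Going by these compounds, whether the two cores answer alike to a ring methyl is unknown, and the two placements are not the same, so the measured step is only a loose guide.

The step from compound 3 to compound 4 is expected to be an at least 10-fold lower number from compound 3 to compound 4 (1.00 log units; beyond the scatter). That expectation rests on compound 3 standing at the limit > 100 mg/kg and on the large measured step of an at least 500-fold lower number from compound 1 to compound 2 (2.69 log units; beyond the scatter). Compound 4 is estimated at 10 mg/kg, with a range from 1 mg/kg to 150 mg/kg, and a limit may again be all that is reported.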

Compound 4, dose for half-maximal effect: > 100 mg/kg
Compound 4 was reported as a limit (the forecaster's own chance of this, stated with the estimate: 35%); at least 10-fold (1.00 log units) between middle value and limit.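

Compound 3 and compound 4 both stand at a limit of this assay, so no step between them can be read: the limit of > 100 mg/kg in this assay, at which 3 of the 4 values shown sit.

The compounds shown leave open what the methyl does on the core of compound 3, and whether the placement of the methyl or the difference in core sets this pair apart from compound 1 and compound 2.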